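Lengthening the Chain of Compound 3

The source may hold more compounds than are shown below. What is called first, only, known or untested is meant among the compounds shown, and "the series" means these compounds.

In a functional assay on A549 cells (Homo sapiens) for cytotoxicity, read by MTT assay, with a stated time of 72 h (on this read-out lower numbers stand for stronger inhibition and higher numbers for weaker inhibition), compound 3 (`CN1CCN(CCCn2c3c(c4ccccc42)C(=O)c2c[n+]([O-])c4ccccc4c2C3=O)CC1`) gives 140 nM, compound 1 (`CN(C)CCCCCn1c2c(c3ccccc31)C(=O)c1c[n+]([O-])c3ccccc3c1C2=O`) gives 210 nM and compound 2 (`CCCCN1CCN(CCCCn2c3c(c4ccccc42)C(=O)c2c[n+]([O-])c4ccccc4c2C3=O)CC1`) gives 550 nM. Compound 3 therefore sits level with compound 1, as a 1.5-fold lower number from compound 1 to compound 3 (0.18 log units; within the scatter) shows, while compound 2 stands apart, with a 3.9-fold lower number from compound 2 to compound 3 (0.59 log units; beyond the scatter). Compound 4 (`CN1CCN(CCCCCCn2c3c(c4ccccc42)C(=O)c2c[n+]([O-])c4ccccc4c2C3=O)CC1`) differs from compound 3 by 3-(4-methylpiperazin-1-yl)propyl in place of 4-methylpiperazin-1-yl on a saturated chain carbon, three bonds along the chain from an aromatic nitrogen. Going by the values given here, no measured step isolates this change, so the nearest guides are the modest 3.9-fold lower number from compound 2 to compound 3 (0.59 log units; beyond the scatter) and a 2.6-fold higher number from compound 1 to compound 2 (0.42 log units; beyond the scatter). A modest rise is expected in this assay, estimated as a 2.1-fold higher number from compound 3 to compound 4 (0.33 log units; beyond the scatter). Compound 4 is expected at 300 nM, within an estimated range of 120 nM to 750 nM.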

Compound 4, half-maximal inhibitory concentration: 330 nM
Compound 4: middle estimate off by 1.1-fold (0.04 log units), on the low side; the measured number falls inside the stated range.
By their numbers in this assay, from the lowest: compounds 3, 1, 4 and 2 (each within the scatter of the next, the first and the last beyond it).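

In this assay, extending the chain that carries the 4-methylpiperazin-1-yl group gives a 2.4-fold higher number from compound 3 to compound 4 (0.37 log units; beyond the scatter) and so shows, with the terminal group held constant, that chain length alone moves the number. Even so, the longer chain does not set compound 4 apart from the other two compounds, with a 1.7-fold lower number from compound 2 to compound 4 (0.22 log units; within the scatter) and a 1.6-fold higher number from compound 1 to compound 4 (0.20 log units; within the scatter). Nothing available accounts for the rise.

The compounds shown leave open how a shorter chain or a still longer chain would read, and whether a morpholine in place of the 4-methylpiperazin-1-yl group would follow the same course.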